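Benzylamide to anilide switch on the chromone acrylamide series

The compounds below may be only part of what the source reports. "The series", "measured", "known", "first", "only" and "open" are said of these compounds alone.

Compound 1 `COc1ccc2c(=O)c(/C=C/C(=O)NCc3cccc(F)c3)coc2c1`, compound 2 `COc1ccc2c(=O)c(/C=C/C(=O)NCc3ccc(F)cc3)coc2c1` and compound 3 `COc1ccc2c(=O)c(/C=C/C(=O)NCc3ccc(F)cc3F)coc2c1` share one core and differ only in the fluorinated benzyl group on the amide nitrogen. In a functional assay (QGY7701 cells, Homo sapiens) for inhibition, read by MTT assay, with a stated time of 48 h (a higher number here means a weaker inhibitor, a lower number a stronger inhibitor), compound 1 gives 28600 nM. In this assay compound 2 gives 7960 nM, a step of a 3.6-fold lower number from compound 1 to compound 2 (0.56 log units; beyond the scatter). For compound 3 this assay reports only a limit, > 100000 nM, which is the limit of > 100000 nM in this assay, at which 1 of the 3 values shown sits. Against compound 1 that gives an at least 3.4-fold higher number from compound 1 to compound 3 (0.54 log units; beyond the scatter), and against compound 2 it gives an at least 12-fold higher number from compound 2 to compound 3 (1.09 log units; beyond the scatter). Compound 3 thus stands at the weak end of the three, known only as a limit.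

Compound 4 `COc1ccc2c(=O)c(/C=C/C(=O)Nc3ccc(C)cc3)coc2c1` is not yet measured in this assay. The change is 4-methylphenyl in place of 2,4-difluorobenzyl on an amide-type nitrogen, on an amide-type nitrogen whose other neighbour is the carbonyl carbon. None of the three measured steps bears directly on it: all of them move fluorine about a benzyl ring, none removes the saturated chain carbon or puts a methyl on the ring. Given that compound 2 gives 7960 nM and compound 1 gives 28600 nM, compound 4 is expected to return to that range rather than stay where compound 3 does. The step from compound 3 is accordingly expected as an at least 3.3-fold lower number from compound 3 to compound 4 (0.52 log units; beyond the scatter). Compound 4 is estimated at 30000 nM, with a range from 8000 nM to 110000 nM.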

Compound 4, half-maximal inhibitory concentration: 39300 nM
For compound 4 the middle estimate is 1.3-fold (0.12 log units) below the measured one; measured number inside the range.
By their numbers in this assay, from the lowest: compound 2; then compounds 1 and 4 (each within the scatter of the next). At a limit, above all of these: compound 3.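

With 4-methylphenyl on the amide-type nitrogen in place of 2,4-difluorobenzyl, this assay again gives a number, and the change amounts to an at least 2.5-fold lower number from compound 3 to compound 4 (0.40 log units; beyond the scatter), a step that rests on a limit, as compound 3 is known only as one: the limit of > 100000 nM in this assay, at which 1 of the 4 values shown sits.

Against 4-fluorobenzyl the same kind of change gives a 4.9-fold higher number from compound 2 to compound 4 (0.69 log units; beyond the scatter), so compound 2 stays the strongest of the four. Against 3-fluorobenzyl it gives a 1.4-fold higher number from compound 1 to compound 4 (0.14 log units; within the scatter), so the saturated chain carbon is not needed to reach the level of compound 1, and the benzyl groups do not all fall on the same side of the 4-methylphenyl group.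

These steps remove the chain carbon and exchange fluoro for methyl in one move, so the two contributions stay unseparated; a 4-fluorophenyl or a 4-methylbenzyl group on the same nitrogen would divide them. Also open, as far as these compounds go, is how the series responds to a longer chain such as 2-phenylethyl, or to an amine or a carboxylic acid on the aromatic ring.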